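Compound 1 and its 1-phenylethyl counterpart

The source may hold more compounds than are shown below. What is called first, only, known or untested is meant among the compounds shown, and "the series" means these compounds.

Three compounds share one core and were tested in a functional assay on CHO cells for activation of 5-hydroxytryptamine receptor 1D (Homo sapiens), read by GTPgammaS binding; a lower number here means a smaller maximal response, a higher number a larger maximal response. Compound 1 `OC[C@H](NC1CCN(CCCc2c[nH]c3ccc(-n4ccnc4)cc23)CC1)c1ccccc1` gives 74%. Compound 2 `c1ccc2c(c1)CCC2NC1CCN(CCCc2c[nH]c3ccc(-n4cnnc4)cc23)CC1` gives 68%, and compound 3 `OC[C@H](NC1CCN(CCCc2c[nH]c3ccc(Cn4cncn4)cc23)CC1)c1ccccc1` gives 76%. For the measured compounds named here, compound 1 thus sits between its two neighbours, yet all three numbers fall within the scatter of one another: the single step between measured compounds, a number 2 percentage points higher from compound 1 to compound 3 (within the scatter), comes from exchanging one ring substituent on the core and changes nothing beyond the scatter.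

Compound 4 `C[C@@H](NC1CCN(CCCc2c[nH]c3ccc(-n4ccnc4)cc23)CC1)c1ccccc1` has not been measured. It differs from compound 1 at the amine nitrogen: 1-phenylethyl in place of 2-hydroxy-1-phenylethyl on an amine nitrogen. Going by the values given here, none of the measured steps touches this part of the molecule, so there is no direct guide. Among the compounds with values here, the one step that exists, a number 2 percentage points higher from compound 1 to compound 3 (within the scatter), suggests the core tolerates small changes without altering the maximal response. The step to compound 4 is therefore expected to be no change at the digits printed from compound 1 to compound 4 (within the scatter), nothing beyond the scatter. Compound 4 is estimated at 74%, within a range from 60% to 88%.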

Compound 4, largest response reached (reported as efficacy), in percent of the reference or control that the assay uses: 65%
The estimate for compound 4 lay 9 percentage points above the measured number; the measured number falls inside the stated range.
By their numbers in this assay, from the lowest: compounds 4, 2, 1 and 3 (each within the scatter of the next, the first and the last beyond it).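

The step at the amine nitrogen is the first among these compounds to touch this part of the molecule: in this assay, 1-phenylethyl in place of 2-hydroxy-1-phenylethyl gives a number 9 percentage points lower from compound 1 to compound 4 (within the scatter). The maximal response therefore does not depend measurably on the hydroxy group of this substituent, and the substituent on the amine nitrogen joins the aromatic substituent of the shared core as a place where a single exchange has stayed within the scatter. Nothing shown accounts for the size of this step.

On these data alone, it remains open whether a group that replaces the hydroxy group, such as a methoxy group, an amine or a carboxylic acid, would leave the response equally undisturbed. Also open, as far as these compounds go, is whether the same exchange would give a similar step on the core of compound 3, with its (1H-1,2,4-triazol-1-yl)methyl group.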